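The source may report more compounds than this note shows. Statements on the series, on what has been measured and on what is new or still open speak of the compounds shown alone.

In a functional assay on HL-60 cells (Homo sapiens) for antiproliferative activity, read by MTT assay, with a stated time of 48 h (on this read-out higher numbers stand for weaker inhibition and lower numbers for stronger inhibition), compound 1 (`O=C(CCCCCC(=O)Nc1ccc(O)c(C(=O)Nc2ccc(F)c(F)c2)c1)NO`) gives > 100000 nM, which is a limit and not a number. Compound 2 (`C#Cc1cccc(NC(=O)c2cc(NC(=O)CCCCCC(=O)NO)ccc2O)c1`) gives > 100000 nM, which is also a limit. The two measured compounds therefore share one mark, (the limit of > 100000 nM in this assay, at which 2 of the 2 values shown sit), and compound 1 has no numeric position in the series.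

Among the compounds with values here, the only measured step is a step that the two limits leave unreadable from compound 1 to compound 2, with 3-ethynylphenyl in place of 3,4-difluorophenyl on an amide-type nitrogen. It supplies no size that can be carried forward.

Compound 3 (`O=C(CCCCCC(=O)Nc1ccc(O)c(C(=O)Nc2ccc(Cl)c(Cl)c2)c1)NO`) has 3,4-dichlorophenyl in place of 3,4-difluorophenyl on that same amide-type nitrogen: 3,4-dichlorophenyl in place of 3,4-difluorophenyl on an amide-type nitrogen. With no readable step to draw on, no shift beyond the scatter and no direction can be forecast in this assay. The expectation starts from compound 1 at > 100000 nM, and that starting point is a limit. The estimated change is a number no higher from compound 1 to compound 3 (the limit leaves the size open), which is expected to stay within the scatter. Another report as a limit is the likeliest outcome. For compound 3 the expected value is 100000 nM, with an estimated range of 40000 nM to 250000 nM.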

Compound 3, half-maximal inhibitory concentration: > 100000 nM
Compound 3: a limit, no number; the forecaster's own chance of this, stated with the estimate: 85%; the middle value sits exactly at the limit.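

No new step can be read in this assay: compound 3 pairs with compound 1 and with compound 2 only through limits, so neither pair gives a size. The compounds shown leave open whether any group on the amide-type nitrogen changes the read-out, as all of them share one mark: the limit of > 100000 nM in this assay, at which 3 of the 3 values shown sit.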